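The source may hold more compounds than are shown below. What is called first, only, known or untested is meant among the compounds shown, and "the series" means these compounds.

Compound 1 `COc1ccc(Cn2nncc2-c2cc(OC)c(OC)c(OC)c2)cc1` is the starting point; in a functional assay on K562 cells (Homo sapiens) for cytotoxicity, read by MTT assay, with a stated time of 5 days (a higher number here means a weaker inhibitor, a lower number a stronger inhibitor), compound 1 gives 8660 nM. Compound 2 `COc1ccc(Cn2nncc2-c2cc(OC)c(OC)c(OC)c2)cc1O` adds a hydroxy to the same core, and in this assay compound 2 gives 1830 nM, which is the lower of the two numbers shown. Among the compounds with values here, that single step, a 4.7-fold lower number from compound 1 to compound 2 (0.68 log units; beyond the scatter), is the only measured change here, and it places compound 2 as the stronger of the two.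

Compound 3 `COc1ccc(Cn2nncc2-c2cc(OC)c(OC)c(OC)c2)cc1[N+](=O)[O-]` is the next step: nitro in place of hydroxy on an aromatic carbon. The hydroxy that set compound 2 apart from compound 1 leaves, and a nitro enters on that aromatic carbon. Within the data shown here, no measured pair shows a nitro, so the only guide is that removing the hydroxy would undo the gain seen from compound 1 to compound 2. The number for compound 3 is therefore expected to rise, with a 2.5-fold higher number from compound 2 to compound 3 (0.39 log units; beyond the scatter) as the estimated step. Compound 3 is estimated at 4500 nM, within 1500 nM to 13000 nM.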

Compound 3, half-maximal inhibitory concentration: > 10000 nM
Compound 3: only a limit was reported; the forecaster's own chance of this, stated with the estimate: 5%; at least 2.2-fold (0.34 log units) between middle value and limit.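

In this assay compound 3 gives only a limit, not a number: the limit of > 10000 nM in this assay, at which 1 of the 3 values shown sits.

Even so, the position proves sensitive to which group it carries, since the change shows an at least 5.4-fold higher number from compound 2 to compound 3 (0.73 log units; beyond the scatter), so the gain seen with the hydroxy does not carry over to the nitro. Set against plain hydrogen, the nitro brings no visible gain, and the result reads an at least 1.1-fold higher number from compound 1 to compound 3 (0.06 log units; that floor lies within the scatter), which leaves compound 3 and compound 1 unranked.

The hydroxy has a hydrogen-bond donor and the nitro has none, but this one swap cannot show whether that difference is what matters, as the nitro also differs in size and atoms. An amine or a fluorine on the same aromatic carbon would help show whether the gain is special to the hydroxy.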